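Dioxolane-piperidines: chloro to hydroxy on the aryl ring

The source may hold more compounds than are shown below. What is called first, only, known or untested is meant among the compounds shown, and "the series" means these compounds.

Measured so far in a functional assay (brain) for displacement of a labelled ligand, with Rattus norvegicus as the target; a lower number here means a stronger inhibitor, a higher number a weaker inhibitor:
compound 1 `CCCC[C@]1(c2ccccc2)OC[C@H]([C@@H]2CCCCN2)O1` gives 200 nM
compound 2 `CCCCCCCCC[C@]1(c2ccccc2)OC[C@H]([C@@H]2CCCCN2)O1` gives 43000 nM
compound 3 `CC[C@]1(c2ccccc2Cl)OC[C@H]([C@@H]2CCCCN2)O1` gives 14.3 nM

Compound 3 holds the lowest number of the three measured in this assay; compound 1 stands nearest, and compound 2 furthest. Compound 4 `CC[C@]1(c2ccccc2O)OC[C@H]([C@@H]2CCCCN2)O1` has not been measured. Its structure differs from that of compound 3 in one place: hydroxy in place of chloro on an aromatic carbon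

Among the compounds with values here, only one single-point step has been measured, a 220-fold higher number from compound 1 to compound 2 (2.33 log units; beyond the scatter), and it concerns the chain on the saturated carbon, not the aryl ring. Within the data shown here, no measured pair separates a chloro from a hydroxy on the aromatic ring, and no measured pair shows an aryl ring carrying a group that donates a hydrogen bond. The expectation for compound 4 therefore rests on a general prior rather than on a step within the series: exchange of a halogen for a hydroxy on the aryl ring is expected to cost some affinity, with a wide uncertainty around that. For compound 4 in this assay the estimate is 100 nM, with a range from 20 nM to 600 nM. The step this estimate implies is a 7.0-fold higher number from compound 3 to compound 4 (0.84 log units; beyond the scatter), expected to be beyond the scatter but not certain to be.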

Compound 4, inhibition constant: 293 nM
Estimate against measurement, compound 4: 2.9-fold (0.47 log units) below; measured number inside the range.
By their numbers in this assay, from the lowest: compound 3; then compounds 1 and 4 (each within the scatter of the next); then compound 2.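

In this assay, within the data shown here, the exchange of chloro for hydroxy on the aromatic carbon ortho to a large group gives a 20-fold higher number from compound 3 to compound 4 (1.31 log units; beyond the scatter), the first measured step on the aryl ring rather than on the chain. This position is therefore sensitive to its substituent: replacing one heavy atom with one heavy atom, while adding one hydrogen-bond donor and one hydrogen-bond acceptor by count, produces a large step, and here the chloro compound holds the lower number. Nothing available bears on what lies behind this difference.

The pair alone does not tell whether the step reflects the loss of chloro, the arrival of hydroxy, or both; plain hydrogen at this aromatic carbon would give the reference needed to separate these, and a methoxy group would test the hydroxy oxygen without its hydrogen. Fluoro or bromo at the same carbon would show whether the low number of compound 3 is particular to chloro or extends to other halogens, and the same exchange on a longer chain would show whether the step carries over.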